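The source may hold more compounds than are shown below. What is called first, only, known or untested is meant among the compounds shown, and "the series" means these compounds.

Compound 1, `COc1ccc(-n2nc(-c3ccccc3)nc2CNc2ccc(C(=O)NO)cc2)cc1`, gives 63.4% in an assay on Sf9 cells for inhibition of protein deacetylase HDAC6 (Homo sapiens), read by fluorescence, with a stated time of 40 min, tested at 100 nM; a lower number here means less inhibition, a higher number more inhibition at the concentration tested (going by the name of the read-out).
Compound 2, `O=C(NO)c1ccc(NCc2nc(-c3ccc(Cl)cc3)nn2-c2ccccc2)cc1`, gives 67.2% in this assay.
Compound 3, `O=C(NO)c1ccc(NCc2nc(-c3ccc(F)cc3)nn2-c2ccccc2)cc1`, gives 70.9% in this assay.

Among these three numbers compound 3 holds the highest, yet its gaps to compound 2 and to compound 1 both fall within the usual scatter, so the three compounds cannot be ranked against one another. Among the compounds with values here, the one change made at a single place, a number 3.7 percentage points higher from compound 2 to compound 3 (within the scatter), swaps one halogen for another on the outer ring and moves the number only within the scatter.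

Compound 4, `CC(C)c1ccc(-c2nc(CNc3ccc(C(=O)NO)cc3)n(-c3ccccc3)n2)cc1`, differs from compound 3 at that same ring position: isopropyl in place of fluoro on an aromatic carbon. Within the data shown here, no measured step puts an isopropyl group in place of a halogen, so the only guidance is the halogen swap, which was small. The expectation is therefore a step of a number 4.9 percentage points lower from compound 3 to compound 4 (within the scatter) in this assay, that is, no clear movement beyond the scatter. Compound 4 is estimated to give 66%, with a likely range from 50% to 80%.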

Compound 4, a percentage reported as inhibition, at one concentration (the size of the read-out at that concentration, not a potency): 27.6%
Beside the measured number, compound 4's estimate is 38.4 percentage points above it; the measured number lies below the stated range.
By their numbers in this assay, from the lowest: compound 4; then compounds 1, 2 and 3 (each within the scatter of the next).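

Putting isopropyl in place of fluoro on this aromatic carbon gives a number 43.3 percentage points lower from compound 3 to compound 4 (beyond the scatter) in this assay and is the first clear movement among these compounds, and isopropyl in place of chloro gives a number 39.6 percentage points lower from compound 2 to compound 4 (beyond the scatter) on the same ring. The swap of one halogen for the other, a number 3.7 percentage points higher from compound 2 to compound 3 (within the scatter) in the same assay, gave no hint of this, so the position does respond to what sits on it once the group is changed from a halogen to isopropyl. Nothing available here accounts for the size of this fall.

The compounds shown leave open how a methyl, an amine or a carboxylic acid at this place would read in this assay when set against fluoro and isopropyl. On these data alone, it therefore stays open whether any group other than a halogen brings such a fall, or whether it is tied to isopropyl itself.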